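The source may hold more compounds than are shown below. What is called first, only, known or untested is meant among the compounds shown, and "the series" means these compounds.

In an ADME assay on MT4 cells (Homo sapiens) for cytotoxicity, read by MTT assay, with a stated time of 4 days (a higher number here means that more compound is tolerated, a lower number that less compound is tolerated), compound 1 `Cc1c(Cc2c(F)cccc2F)nc(N(C)C2CCCCC2)[nH]c1=O` reads > 72000 nM, which is a limit of the assay and not a number. Among the measured compounds shown here, compound 2 `Cc1c(Cc2c(F)cccc2F)nc(N2CCCCC2C)[nH]c1=O` gives 75000 nM, the only actual number available so far, so it cannot yet be ranked against another measured value. Compound 3 `Cc1c(Cc2c(F)cccc2F)nc(N2CCC(C)CC2)[nH]c1=O` has the same atoms as compound 2, joined differently, with 4-methylpiperidin-1-yl in place of 2-methylpiperidin-1-yl on an aromatic carbon between two ring nitrogen atoms: 4-methylpiperidin-1-yl in place of 2-methylpiperidin-1-yl on an aromatic carbon. For the measured compounds named here, only one measured step bears on this change, a step that the limit leaves unreadable from compound 1 to compound 2, and its size cannot be read because of the limit of > 72000 nM in this assay, at which 1 of the 2 values shown sits. With compound 2 at 75000 nM as the sole anchor, no step beyond the scatter is expected in this assay, in either direction. The expected step of a 1.2-fold lower number from compound 2 to compound 3 (0.06 log units; within the scatter) is correspondingly small. For compound 3 the estimated value is 65000 nM, with an expected range from 28000 nM to 130000 nM.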

Compound 3, half-maximal cytotoxic concentration: > 75000 nM
Compound 3 gave a limit, no number; the forecaster's own chance of this, stated with the estimate: 35%; middle value at least 1.1-fold (0.06 log units) from the limit.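

In this assay, 4-methylpiperidin-1-yl in place of 2-methylpiperidin-1-yl on the aromatic carbon between two ring nitrogen atoms gives a number no lower from compound 2 to compound 3 (the limit leaves the size open). Compound 3 reads > 75000 nM, which is a limit and not a number. The sizes of all steps among the three compounds therefore cannot be read, and the shift of the methyl group shows only that the number did not fall: the limit of > 75000 nM in this assay, at which 1 of the 3 values shown sits.

The compounds shown leave open whether any group at this position would give a number clearly lower than those seen here. A morpholin-4-yl group, or a piperidin-1-yl group carrying a carboxylic acid or a primary amine, would test this.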